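Acetylation of a free hydroxyl in a cytotoxicity-inactive ester series

The source may hold more compounds than are shown below. What is called first, only, known or untested is meant among the compounds shown, and "the series" means these compounds.

Measured compounds:
compound 1, `COc1ccc(C(=O)O[C@H]2CC(C)=C[C@@H](OC(C)=O)[C@@]3(C)[C@@H](OC(C)=O)C[C@@](O)(C(C)C)[C@H]23)cc1`: in a functional assay on A549 cells (Homo sapiens) for cytotoxicity, read by MTT assay, with a stated time of 72 h (a higher number here means a weaker inhibitor, a lower number a stronger inhibitor), compound 1 gives > 100000 nM, a limit of the assay and not a number.
compound 2, `COc1ccc(C(=O)O[C@H]2CC(C)=C[C@H](OC(C)=O)[C@]3(C)[C@@H]2[C@](O)(C(C)C)C[C@@H]3O)cc1`: in this assay compound 2 gives > 100000 nM, again a limit of the assay and not a number.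

Within the data shown here, compound 2 therefore stands at the upper limit of this assay, and the only other value shown sits at the same limit; the two compounds cannot be ranked against each other (the limit of > 100000 nM in this assay, at which 2 of the 2 values shown sit).

Compound 3, `COc1ccc(C(=O)O[C@H]2CC(C)=C[C@H](OC(C)=O)[C@@]3(C)[C@@H](OC(C)=O)C[C@@](O)(C(C)C)[C@H]23)cc1`, remains to be measured in this assay. It differs from compound 2 in one place: acetyl in place of hydrogen on an oxygen on a saturated carbon. Among the measured compounds shown here, no step between measured compounds is available, so no size of effect for this change can be read from the series.

With both measured values at the limit (the limit of > 100000 nM in this assay, at which 2 of the 2 values shown sit), the expectation for compound 3 is that the step that the limit leaves unreadable from compound 2 to compound 3 stays within the scatter, and that compound 3 is most likely reported as a limit again. Compound 3 is estimated at 150000 nM in this assay, with a range from 40000 nM to 600000 nM.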

Compound 3, half-maximal inhibitory concentration: 23300 nM
Compound 3: the middle estimate sits 6.4-fold (0.81 log units) above what was measured; the measured number lies below the stated range.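

In this assay, among these compounds, hydroxy to acetoxy at this position yields the first readable number, with an at least 4.2-fold lower number from compound 2 to compound 3 (0.63 log units; beyond the scatter). The acetyl group alone does not account for this, as compound 1 carries the same atoms and bonds yet shows an at least 4.2-fold lower number from compound 1 to compound 3 (0.63 log units; beyond the scatter), so the configuration at one saturated ring carbon also separates a readable value from a limit: the fact that compounds 1 and 3 differ only in the configuration as drawn. Both steps start from a limit of the assay, so each gives only the smallest possible size of the change, and the full size cannot be read: the limit of > 100000 nM in this assay, at which 2 of the 3 values shown sit.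

The compounds shown leave open whether the acetyl group is specifically required on this oxygen, or whether a longer chain such as butyryl, or a methyl ether, would give a readable number as well. They also leave open whether the 4-methoxybenzoate ester elsewhere on the shared core contributes to the value of compound 3, which a plain benzoate or a free hydroxy at that place would begin to test.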